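Triazolylmethyl series: trifluoromethyl versus methyl on the aryl

A few compounds are considered here, and "the series" means these few. Any claim that something is new, unique, unknown or untested is made for them only; others in the source may bear on it.

Measured in a functional assay on SW480 cells (Homo sapiens) for cytotoxicity, read by MTT assay, with a stated time of 4 days; on this read-out lower numbers stand for stronger inhibition and higher numbers for weaker inhibition:
- compound 1 `C=C1C(=O)[C@]23C[C@@]1(O)CC[C@H]2c1ccc(O)c(C)c1[C@@H]3Cn1cc(-c2ccc(C(F)(F)F)cc2)nn1`: 370 nM
- compound 2 `C=C1C(=O)[C@]23C[C@@]1(O)CC[C@H]2c1ccc(O)c(C)c1[C@@H]3Cn1cc(-c2ccc(C)cc2)nn1`: 330 nM
- compound 3 `Cc1ccc(-c2cn(C[C@H]3c4c(ccc(OS(=O)(=O)c5ccc(C)cc5)c4C)[C@@H]4CC[C@@]5(C)C[C@]43CC5=O)nn2)cc1`: only a limit, > 20000 nM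

Compound 1 and compound 2 share one core and differ by trifluoromethyl in place of methyl on an aromatic carbon; the step of a 1.1-fold higher number from compound 2 to compound 1 (0.05 log units; within the scatter). Compound 3 carries a different core, and the difference between the two cores is not broken down here. Compound 4 `Cc1ccc(S(=O)(=O)Oc2ccc3c(c2C)[C@H](Cn2cc(-c4ccc(C(F)(F)F)cc4)nn2)[C@@]24CC(=O)[C@@](C)(CC[C@@H]32)C4)cc1` is not yet measured; it differs from compound 3 by trifluoromethyl in place of methyl on an aromatic carbon, the same change as from compound 2 to compound 1. The value of compound 3 in this assay is a limit, and of the three values shown (the limit of > 20000 nM in this assay, at which 1 of the 3 values shown sits). The change is expected to move compound 4 little against compound 3, with a step that the limit leaves unreadable from compound 3 to compound 4, because the matched step a 1.1-fold higher number from compound 2 to compound 1 (0.05 log units; within the scatter) lies within the scatter. Compound 4 is therefore estimated at 25000 nM, the plausible range 8000 nM to 80000 nM, and most likely the assay again reports only a limit.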

Compound 4, half-maximal inhibitory concentration: > 20000 nM
Compound 4 gave a limit, no number (the forecaster's own chance of this, stated with the estimate: 80%); the middle value lies beyond the limit too.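

Compound 3 and compound 4 both give only a limit, so no step between them can be read: the limit of > 20000 nM in this assay, at which 2 of the 4 values shown sit.

Still open, on these data alone, is which part of the difference between the two cores separates compound 2 from compound 3.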